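The source may hold more compounds than are shown below. What is called first, only, known or untested is meant among the compounds shown, and "the series" means these compounds.

Compound 1, with structure `N#C[Se]c1ccc(NC(=O)Oc2ccc(F)cc2)cc1`, and compound 2, with structure `CCOC(=O)Nc1ccc([Se]C#N)cc1`, belong to a small set of selenocyanate carbamates tested in a functional assay on PC-3 cells (Homo sapiens) for cytotoxicity, read by MTT assay, with a stated time of 72 h; a higher number here means a weaker inhibitor of growth, a lower number a stronger inhibitor of growth. In this assay compound 1 gives 40400 nM, and compound 2 gives 39200 nM. Among the two values shown, compound 2 holds the lower number, but the gap to compound 1 lies within the usual scatter of the measurement, so the two cannot be told apart on these data alone.

Compound 3, with structure `N#C[Se]c1ccc(NC(=O)Oc2ccccc2)cc1`, has not yet been measured in this assay. It differs from compound 2 in one place: phenyl in place of ethyl on an oxygen next to a carbonyl group. That is, a phenyl takes the place of the ethyl on the oxygen next to the carbonyl group, while the rest of the shared core remains the same.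

Compound 1 already carries an aromatic group in that position and sits within the scatter of compound 2, so the expected step in this assay from compound 2 to compound 3 is a 1.0-fold higher number from compound 2 to compound 3 (0.01 log units; within the scatter), meaning no change beyond the scatter. Compound 3 is therefore estimated at 40000 nM, with a range from 20000 nM to 80000 nM.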

Compound 3, concentration for total growth inhibition: 37500 nM
Beside the measured number, compound 3's estimate is 1.1-fold (0.03 log units) above it; the range from low to high includes it.
By their numbers in this assay, from the lowest: compounds 3, 2 and 1 (each within the scatter of the next).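

Putting a phenyl in place of the ethyl on the oxygen next to a carbonyl group gives a 1.0-fold lower number from compound 2 to compound 3 (0.02 log units; within the scatter) in this assay, so a short open chain and a six-membered aromatic ring of carbon cannot be told apart at this position, despite the added heavy atoms. Within the data shown here, compound 3 also isolates the fluoro group for the first time: hydrogen in place of fluoro on an aromatic carbon gives a 1.1-fold lower number from compound 1 to compound 3 (0.03 log units; within the scatter), so this change makes no readable difference either. No measurement is available that would explain why these changes leave the read-out within the scatter.

From the compounds shown here alone, the three compounds cover only ethyl, phenyl and fluorophenyl on that oxygen, so it remains open whether a longer chain such as hexyl, or a chain ending in an amine or a carboxylic acid, would shift the number beyond the scatter. Going by these compounds, it also remains open whether a group other than fluoro on the aromatic ring, such as methoxy or nitro, would do so, and how much of the growth inhibition depends on the selenocyanate, since all three compounds carry it.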